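Ethylamino to isopropylamino on a second halogenated core

This account rests on a few compounds, and the source may have more. Where it says the series, first, only, none or still open, it means among the compounds named here.

In a functional assay (aorta) with Rattus norvegicus as the target, with a stated time of 90 min, at 37 degrees C (on this read-out higher numbers stand for an effect only at larger amounts of compound and lower numbers for an effect already at smaller amounts), compound 1 `CCNC1=NS(=O)(=O)c2cc(Br)c(Cl)cc2N1` gives 3300 nM. Compound 2 `CC(C)NC1=NS(=O)(=O)c2cc(Br)c(Cl)cc2N1` carries methyl in place of hydrogen on a saturated chain carbon bound to an amine nitrogen and a saturated chain carbon and in this assay compound 2 gives 5600 nM; the step is a 1.7-fold higher number from compound 1 to compound 2 (0.23 log units; within the scatter). Compound 3 `CCNC1=NS(=O)(=O)c2cc(F)c(F)cc2N1` keeps the ethylamino group of compound 1 on another core; the difference between the two cores is not broken down here. In this assay compound 3 gives 66700 nM, the highest number of the three, beyond the scatter from both compound 1 and compound 2. Compound 4 `CC(C)NC1=NS(=O)(=O)c2cc(F)c(F)cc2N1` is not yet measured and carries methyl in place of hydrogen on a saturated chain carbon bound to an amine nitrogen and a saturated chain carbon, the same change as that from compound 1 to compound 2. A step of similar size is expected for compound 4, a 1.5-fold higher number from compound 3 to compound 4 (0.18 log units; within the scatter), because the earlier one was a 1.7-fold higher number from compound 1 to compound 2 (0.23 log units; within the scatter). Compound 4 is thus estimated at 100000 nM in this assay, between 45000 nM and 250000 nM.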

Compound 4, half-maximal effective concentration: 102000 nM
Compound 4: middle estimate off by 1.0-fold (0.01 log units), on the low side, within the range that was stated.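

In this assay, ethylamino to isopropylamino gives a 1.5-fold higher number from compound 3 to compound 4 (0.18 log units; within the scatter). The size of the step carries over from one core to the other with no difference that can be read: the same change on two cores in this assay, a 1.7-fold higher number (0.23 log units; within the scatter) from compound 1 to compound 2 and a 1.5-fold higher number (0.18 log units; within the scatter) from compound 3 to compound 4, 1.1-fold (0.05 log units) apart, within the scatter of two such steps
Both steps lie within the scatter, so neither pair establishes an effect of the change itself, and agreement on two cores says nothing about how the change behaves on any other core.

From the compounds shown here alone, whether a longer chain, such as butyl, or a ring, such as cyclopropyl, in place of the ethyl group would give a step beyond the scatter remains open. Also open, going by these compounds, is how the same change behaves on a core with methoxy or nitrile in place of the halogens.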